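The compounds below may be only part of what the source reports. "The series", "measured", "known", "first", "only" and "open" are said of these compounds alone.

Measured compounds in hand:
compound 1, `SC1=NNCC(n2c(-c3ccco3)nc3ccccc32)=N1`: 62100 nM
compound 2, `O=C(Cn1c(-c2ccco2)nc2ccccc21)N/N=C/c1ccccc1Cl`: 26000 nM
compound 3, `N#C/C(=C1/SCC(=O)N1c1ccccc1)n1c(-c2ccco2)nc2ccccc21`: 39600 nM

All three numbers come from a functional assay on HepG2 cells (Homo sapiens) for cytotoxicity, read by sulforhodamine B assay, with a stated time of 48 h; a lower number here means a stronger inhibitor, a higher number a weaker inhibitor. Compound 1 gives the highest of the three; compound 3 lies within the scatter of it, while compound 2 sits beyond the scatter at a lower number. The step to compound 4, `N#CCn1c(-c2ccco2)nc2ccccc21`, changes one place on the shared core: a group of 3 heavy atoms (2 carbon, 1 nitrogen; no ring) in place of a group of 7 heavy atoms (3 carbon, 3 nitrogen, 1 sulfur; one six-membered non-aromatic ring with 3 hetero atoms), on an aromatic nitrogen. For the measured compounds named here, no step between two measured compounds of this kind is available, so the size of this change cannot be read from the series itself. A modest move toward a higher number in this assay, or none beyond the scatter, is expected, as a 1.2-fold higher number from compound 1 to compound 4 (0.08 log units; within the scatter). For compound 4 the estimate in this assay is 75000 nM, within 25000 nM to 220000 nM.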

Compound 4, half-maximal inhibitory concentration: 88100 nM
Estimate against measurement, compound 4: 1.2-fold (0.07 log units) below; the range from low to high includes it.
By their numbers in this assay, from the lowest: compounds 2, 3, 1 and 4 (each within the scatter of the next, the first and the last beyond it).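

On the aromatic nitrogen of the shared core, cyanomethyl in place of the six-membered non-aromatic ring with 3 hetero atoms gives a 1.4-fold higher number from compound 1 to compound 4 (0.15 log units; within the scatter) in this assay, the first single-place step read at this position. The ring, its sulfur and its 2 hydrogen-bond donors can therefore leave this position without a shift beyond the scatter. Nothing measured here bears on the reason for this result.

From the compounds shown here alone, whether an amine or a carboxylic acid on a longer chain at this nitrogen would shift the number beyond the scatter stays open. So does the outcome of replacing the furan-2-yl group while this position stays fixed.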